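The compounds below may be only part of what the source reports. "The series", "measured", "known", "first", "only" and "open" are said of these compounds alone.

- Compound 1 `O=C1/C(=C/c2ccccc2)CCC/C1=C\c1ccccc1[N+](=O)[O-]`: 3800 nM
- Compound 2 `CN(C)c1ccc(/C=C2\CCC/C(=C\c3ccccc3[N+](=O)[O-])C2=O)cc1`: > 400000 nM
- Compound 3 `O=C1/C(=C/c2ccc(Cl)cc2)CCC/C1=C\c1cccc([N+](=O)[O-])c1`: 2200 nM

These three compounds were tested in a functional assay on HSC-2 cells (Homo sapiens) for cytotoxicity, with a stated time of 24 h; a lower number here means that less compound is tolerated, a higher number that more compound is tolerated. Compound 3 gives 2200 nM and compound 1 gives 3800 nM, two values within the usual scatter of each other. Compound 2 reads > 400000 nM, which is a limit of the assay and not a number.

The next compound, compound 4 `Cc1ccc(/C=C2\CCC/C(=C\c3cccc([N+](=O)[O-])c3)C2=O)cc1`, departs from compound 3 in one place: methyl in place of chloro on an aromatic carbon. In words, methyl takes the place of chloro on an aromatic carbon.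

Among the measured compounds shown here, only one measured step offers any guide, and that is an at least 100-fold higher number from compound 1 to compound 2 (2.02 log units; beyond the scatter). It is a large step, and it also happens on an aromatic carbon, but it puts dimethylamino in place of hydrogen, a different exchange from the one here. It also starts from compound 1, which is not the parent of compound 4. For the measured compounds named here, no measured pair swaps chloro for methyl, so this step says little about the present change. It does show that a substituent on this kind of ring can matter, which justifies a fairly wide range. With no closer evidence, no shift beyond the scatter is expected in this assay, with at most a slight lean towards a higher number.

The estimated change is a 1.4-fold higher number from compound 3 to compound 4 (0.13 log units; within the scatter). For compound 4 the expected value is 3000 nM, within an estimated range of 1000 nM to 9000 nM.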

Compound 4, half-maximal cytotoxic concentration: 17000 nM
The estimate for compound 4 lay 5.7-fold (0.75 log units) below the measured number, and the stated range ends below it.
By their numbers in this assay, from the lowest: compounds 3 and 1 (each within the scatter of the next); then compound 4. At a limit, above all of these: compound 2.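

In this assay there is a 7.7-fold higher number from compound 3 to compound 4 (0.89 log units; beyond the scatter) and this shows that the group on the 4-chlorophenyl ring is not a neutral place to make a change, even though chloro and methyl match in heavy-atom count and neither carries a hydrogen-bond donor or acceptor. Among the compounds shown here, the only earlier step, an at least 100-fold higher number from compound 1 to compound 2 (2.02 log units; beyond the scatter) and with dimethylamino in place of hydrogen, involved adding a whole new group, whereas this one shows that a one-for-one swap on an aromatic carbon is enough to move the number beyond the scatter. Compound 2 reads > 400000 nM and that value is a limit of the assay and not a number.

On these data alone, it remains open how fluoro, methoxy, an amine or a carboxylic acid would behave in this same place, and whether the swap from chloro to methyl would move the number as far if the nitro group stood where it does in compound 1. The information at hand offers no explanation for why methyl and chloro differ in this step.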